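Oxolanyl amide in place of methylcyclohexyl on the azetidine series

A few compounds are considered here, and "the series" means these few. Any claim that something is new, unique, unknown or untested is made for them only; others in the source may bear on it.

Of the compounds shown here, three of one series have been measured in an assay on HEK293 cells for positive allosteric modulation of metabotropic glutamate receptor 5 (Homo sapiens), read by FLIPR; on this read-out higher numbers stand for an effect only at larger amounts of compound and lower numbers for an effect already at smaller amounts. Compound 1 `O=C(C1CCC(F)(F)CC1)N1CC(c2nc(-c3cccc(F)c3)no2)C1` gives 520 nM. Compound 2 `O=C(c1ccccc1F)N1CC[C@H]1c1nc(-c2cccc(F)c2)no1` reaches only the limit of the assay, > 10000 nM, and so supplies no number; that limit is recorded as the limit of > 10000 nM in this assay, at which 1 of the 3 values shown sits. Compound 3 `CC1CCCC(C(=O)N2CC(c3nc(-c4cccc(Cl)c4)no3)C2)C1` gives 410 nM, the lowest of the two numbers, though its gap to compound 1 stays within the usual scatter, so the two cannot be ordered.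

Compound 4 `O=C(C1CCCO1)N1CC(c2nc(-c3cccc(Cl)c3)no2)C1` has not yet been measured. It differs from compound 3 in one place: oxolan-2-yl in place of 3-methylcyclohexyl on a carbonyl carbon. Within the data shown here, no measured pair in this set carries a comparable exchange, so the size of this step has no direct precedent. Among the measured compounds shown here, a moderate step toward higher numbers is expected, because the only two numbers available, 410 nM for compound 3 and 520 nM for compound 1, both belong to amides with six-membered carbon rings. The estimate for compound 4 in this assay is 1500 nM, between 400 nM and 6000 nM, which would mean an expected step of a 3.7-fold higher number from compound 3 to compound 4 (0.56 log units; beyond the scatter).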

Compound 4, half-maximal effective concentration: > 10000 nM
Compound 4 ended at the assay's limit; the forecaster's own chance of this, stated with the estimate: 20%; middle value at least 6.6-fold (0.82 log units) away from the limit.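

In this assay, putting oxolan-2-yl in place of 3-methylcyclohexyl on a carbonyl carbon gives an at least 24-fold higher number from compound 3 to compound 4 (1.38 log units; beyond the scatter), so the group on this carbonyl carbon can decide whether the series gives a number at all. Compound 4 gives a limit of the assay and not a number, and it is the second compound shown to do so: the limit of > 10000 nM in this assay, at which 2 of the 4 values shown sit. Compound 3 could not show how much depends on this place, whereas this single exchange shows that the effect can be lost here while the rest of the structure stays the same.

The exchange changes ring size and brings in a ring oxygen at once, and the compounds shown do not separate these two changes. A cyclopentyl amide and an oxan-4-yl amide on the same core would tell them apart.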